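A few compounds are considered here, and "the series" means these few. Any claim that something is new, unique, unknown or untested is made for them only; others in the source may bear on it.

The measured compounds are:
- compound 1, `Cc1ccc(C2C(C#N)=C(N)N(c3ccc(S(N)(=O)=O)cc3)C3=C2CCCC3)cc1`, which in a functional assay on Ehrlich cells (Mus musculus) for cytotoxicity, read by trypan blue exclusion, with a stated time of 2 h, tested at 25 ug/mL (on this read-out higher numbers stand for a stronger effect at the one concentration tested and lower numbers for a weaker effect), gives 30%
- compound 2, `N#CC1=C(N)N(c2ccc(S(N)(=O)=O)cc2)C2=C(CCCC2)C1/C=C/c1ccccc1`, which in this assay gives 70%
- compound 3, `COc1ccc(C2C(C#N)=C(N)N(c3ccc(S(N)(=O)=O)cc3)C3=C2CCCC3)cc1`, which in this assay gives 90%

Compound 3 stands highest of the three in this assay; its nearest neighbour is compound 2, reached by a number 20 percentage points higher from compound 2 to compound 3 (beyond the scatter), and the furthest is compound 1, reached by a number 60 percentage points higher from compound 1 to compound 3 (beyond the scatter). Compound 4, `N#CC1=C(N)N(c2ccc(S(N)(=O)=O)cc2)C2=C(CCCC2)C1c1ccc([N+](=O)[O-])cc1`, has not yet been measured. It differs from compound 3 in one place: nitro in place of methoxy on an aromatic carbon.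

The step that bears most on this change is the one on the same aromatic carbon, where a number 60 percentage points higher from compound 1 to compound 3 (beyond the scatter) showed that a change of the group at this position can move the read-out a great deal. For the measured compounds named here, no measured step, however, involves a nitro group, so the direction of the present change is not settled by the data. The step of a number 40 percentage points higher from compound 1 to compound 2 (beyond the scatter) concerns a different part of the molecule and is of less use here. Since compound 3 already stands high, the account expects compound 4 to give a number somewhat lower, a number 25 percentage points lower from compound 3 to compound 4 (beyond the scatter), with wide uncertainty. Compound 4 is therefore estimated at 65%, within a range from 30% to 95%.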

Compound 4, a percentage reported as activity, at one concentration (the size of the read-out at that concentration, not a potency): 5%
Beside the measured number, compound 4's estimate is 60 percentage points above it; the measured number lies below the stated range.
By their numbers in this assay, from the lowest: compound 4; then compound 1; then compound 2; then compound 3.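

At this aromatic carbon, para to a large group, this assay now records a fall as well as a rise: nitro in place of methoxy gives a number 85 percentage points lower from compound 3 to compound 4 (beyond the scatter) while nitro in place of methyl gives a number 25 percentage points lower from compound 1 to compound 4 (beyond the scatter) and the three groups there now read, from the lowest number, nitro, methyl, methoxy. On the saturated ring carbon, the step of a number 65 percentage points lower from compound 2 to compound 4 (beyond the scatter) puts 4-nitrophenyl under 2-phenylethenyl where 4-methoxyphenyl stood over it, so the presence of a substituted phenyl ring in that place does not by itself fix the number, and the group at its far end decides on which side of 2-phenylethenyl it falls. The data at hand offer no measurement that would explain why nitro gives the lowest number of the series.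

Three groups at this carbon are too few to show whether the numbers follow any single trend, and an amine, a hydroxyl, a chlorine atom or a carboxylic acid at the same place would test the order found here. Going by these compounds, it also stays open whether this order holds with the same groups on another carbon of that ring, or at other concentrations and exposure times.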